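A few compounds are considered here, and "the series" means these few. Any claim that something is new, unique, unknown or untested is made for them only; others in the source may bear on it.

Compound 1, `CC(C)=CCOc1ccc2c(c1)OC(c1ccccc1F)CC2=O`: 6360 nM
Compound 2, `CC(C)=CCOc1ccc2c(c1)OC(c1ccccc1Cl)CC2=O`: 8020 nM
Compound 3, `CC(C)=CCOc1ccc2c(c1)OC(c1ccc(Br)cc1)CC2=O`: 8120 nM

All three share one core and differ only in the aromatic ring on a saturated ring carbon. In a functional assay (a higher number here means a weaker inhibitor, a lower number a stronger inhibitor), compound 1 has the lowest number shown, but its steps of a 1.3-fold higher number from compound 1 to compound 2 (0.10 log units; within the scatter) and a 1.3-fold higher number from compound 1 to compound 3 (0.11 log units; within the scatter) both fall within the scatter, so the three cannot be ranked. Compound 4, `CC(C)=CCOc1ccc2c(c1)OC(c1ccc(C)cc1)CC2=O`, carries 4-methylphenyl in place of 2-fluorophenyl on a saturated ring carbon. Among the compounds with values here, the steps that bear on this are the ring swaps at the same place: a 1.3-fold higher number from compound 1 to compound 3 (0.11 log units; within the scatter) and a 1.0-fold higher number from compound 2 to compound 3 (0.01 log units; within the scatter), neither moving beyond the scatter. A methyl on that ring has not been tried here. Compound 4 is therefore expected to sit close to compound 1, a step of a 1.2-fold higher number from compound 1 to compound 4 (0.07 log units; within the scatter). For compound 4 the estimate is 7500 nM, with a range from 3500 nM to 16000 nM.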

Compound 4, half-maximal inhibitory concentration: 4440 nM
The estimate for compound 4 lay 1.7-fold (0.23 log units) above the measured number; low and high end bracket the measured number.
By their numbers in this assay, from the lowest: compounds 4, 1, 2 and 3 (each within the scatter of the next).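

Putting 4-methylphenyl on the saturated ring carbon gives a 1.4-fold lower number from compound 1 to compound 4 (0.16 log units; within the scatter), while the other two comparisons give a 1.8-fold lower number from compound 2 to compound 4 (0.26 log units; within the scatter) and a 1.8-fold lower number from compound 3 to compound 4 (0.26 log units; within the scatter), all in this assay. A ring bearing methyl therefore joins the rings bearing fluoro, chloro and bromo with no step beyond the scatter, so a halogen on this ring is not needed to keep the number in this range. No supporting measurement here offers an explanation for this. As far as these compounds go, whether an amine or a carboxylic acid on this ring would move the number beyond the scatter remains open.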